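Working notes: ethoxy to cyclobutyloxy on the shared core

This account rests on a few compounds, and the source may have more. Where it says the series, first, only, none or still open, it means among the compounds named here.

Measured in a functional assay on MCF7 cells (Homo sapiens) for antiproliferative activity, read by MTT assay, with a stated time of 48 h; a lower number here means a stronger inhibitor, a higher number a weaker inhibitor:
- compound 1 `CCOc1cc(-c2ccc3cc[nH]c3c2)cn2c(-c3cc(OC)c(OC)c(OC)c3)nnc12`: 334 nM
- compound 2 `CCOc1cc(-c2ccc3ccn(C)c3c2)cn2c(-c3cc(OC)c(OC)c(OC)c3)nnc12`: 239 nM
- compound 3 `CCOc1cc(-c2ccc3c(ccn3C)c2)cn2c(-c3cc(OC)c(OC)c(OC)c3)nnc12`: 140 nM

Compound 3 cannot be separated from its nearest neighbour, a 1.7-fold lower number from compound 2 to compound 3 (0.23 log units; within the scatter), and stands apart from the other only modestly, a 2.4-fold lower number from compound 1 to compound 3 (0.38 log units; beyond the scatter). The next structure is compound 4 `COc1cc(-c2nnc3c(OC4CCC4)cc(-c4ccc5c(ccn5C)c4)cn23)cc(OC)c1OC`: cyclobutyl in place of ethyl on an oxygen on an aromatic ring. Among the measured compounds shown here, no measured step touches this oxygen substituent. The available steps, a 1.4-fold lower number from compound 1 to compound 2 (0.15 log units; within the scatter) among them, concern only the indolyl group and its nitrogen, so they bear on the change only indirectly and give no direction. The expected outcome is a 1.3-fold higher number from compound 3 to compound 4 (0.11 log units; within the scatter), with no shift beyond the scatter. Compound 4 is estimated at 180 nM, with an expected range of 70 nM to 500 nM.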

Compound 4, half-maximal inhibitory concentration: 125 nM
For compound 4 the middle estimate is 1.4-fold (0.16 log units) above the measured one, within the range that was stated.
By their numbers in this assay, from the lowest: compounds 4, 3, 2 and 1 (each within the scatter of the next, the first and the last beyond it).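

Putting cyclobutyl in place of ethyl on this oxygen gives no separable change in this assay, with a 1.1-fold lower number from compound 3 to compound 4 (0.05 log units; within the scatter). Among the compounds shown here, the earlier compounds varied only the indolyl group, so this is the first reading at the oxygen, and here it accepts a four-membered non-aromatic ring in place of an open ethyl group. No available measurement bears on the reason for this result.

A single step cannot show how far this tolerance extends, for example to an oxygen substituent carrying an amine, a carboxylic acid or a longer chain. As far as these compounds go, whether cyclobutyloxy behaves alike with the 1-methyl-1H-indol-6-yl group of compound 2 also remains open.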